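A Methyl Group Moved Around the Benzyl Ring

The source may hold more compounds than are shown below. What is called first, only, known or untested is meant among the compounds shown, and "the series" means these compounds.

Compound 1, `O=C1/C(=C\c2ccccc2)c2c(ncn2COCc2ccccc2)CCN1Cc1ccccc1`, is the parent of this small set. In a functional assay on HCT-116 cells (Homo sapiens) for inhibition, read by MTT assay, with a stated time of 72 h (on this read-out lower numbers stand for stronger inhibition and higher numbers for weaker inhibition), compound 1 gives 20000 nM, the highest of the three numbers recorded so far. Compound 2, `Cc1ccc(CN2CCc3ncn(COCc4ccccc4)c3/C(=C/c3ccccc3)C2=O)cc1`, gives 7940 nM in this assay, and compound 3, `Cc1cc(C)cc(CN2CCc3ncn(COCc4ccccc4)c3/C(=C/c3ccccc3)C2=O)c1`, gives 6230 nM. Both methylated compounds improve on compound 1: the step of a 2.5-fold lower number from compound 1 to compound 2 (0.40 log units; beyond the scatter) and the step of a 3.2-fold lower number from compound 1 to compound 3 (0.51 log units; beyond the scatter) point the same way, while the step of a 1.3-fold lower number from compound 2 to compound 3 (0.11 log units; within the scatter) does not separate compound 2 from compound 3.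

Compound 4, `Cc1ccccc1CN1CCc2ncn(COCc3ccccc3)c2/C(=C/c2ccccc2)C1=O`, is the compound still to be measured. Its difference from compound 1 is methyl in place of hydrogen on an aromatic carbon. The measured steps that bear on this change are those from compound 1 to compound 2 and from compound 1 to compound 3, each a modest gain beyond the scatter, and the placement of the methyl did not matter between compound 2 and compound 3. Among the compounds with values here, a similar modest gain is therefore expected in this assay for compound 4, because a 2.5-fold lower number from compound 1 to compound 2 (0.40 log units; beyond the scatter) is the closest precedent.

Compound 4 is expected to give 9000 nM in this assay, within a range from 4000 nM to 20000 nM. That estimate means an expected step of a 2.2-fold lower number from compound 1 to compound 4 (0.35 log units; beyond the scatter).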

Compound 4, half-maximal inhibitory concentration: 24700 nM
Estimate against measurement, compound 4: 2.7-fold (0.44 log units) below; measured number outside the range, above it.
By their numbers in this assay, from the lowest: compounds 3 and 2 (each within the scatter of the next); then compounds 1 and 4 (each within the scatter of the next).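

In this assay the 2-methylbenzyl group of compound 4 shows no separation from the benzyl group of compound 1, with a 1.2-fold higher number from compound 1 to compound 4 (0.09 log units; within the scatter) as the step, so adding a methyl to this ring does not by itself lower the number. The earlier compounds shown here could not show that the place of the methyl counts: compounds 2 and 3 stood within the scatter of each other, whereas 2-methylphenyl in place of 4-methylphenyl gives a 3.1-fold higher number from compound 2 to compound 4 (0.49 log units; beyond the scatter) and 2-methylphenyl in place of 3,5-dimethylphenyl gives a 4.0-fold higher number from compound 3 to compound 4 (0.60 log units; beyond the scatter), both beyond the scatter. Nothing available on these compounds accounts for this difference between the methylated benzyl groups.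

The compounds shown leave open whether this dependence on place belongs to methyl alone or would also appear with a chlorine atom or a methoxy group on the same ring carbon as the methyl of compound 4. They also leave open how a hydroxyl group or an amine on the benzyl ring would behave in this assay at either of the places already tested.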